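Three Compounds at the Assay Limit, a Fourth Expected There

A few compounds are considered here, and "the series" means these few. Any claim that something is new, unique, unknown or untested is made for them only; others in the source may bear on it.

Measured so far in a functional assay on HT-29 cells (Homo sapiens) for cytotoxicity, read by MTT assay, with a stated time of 72 h; on this read-out higher numbers stand for lower toxicity in this test and lower numbers for higher toxicity in this test:
Compound 1 `CS/C(=N\C(=O)c1csc([N+](=O)[O-])c1)NC(=O)c1csc([N+](=O)[O-])c1` gives > 100000 nM, which is a limit of the assay and not a number.
Compound 2 `O=C(/N=C(/NC(=O)c1cccs1)[Se]Cc1ccccc1)c1cccs1` gives > 100000 nM, again a limit of the assay.
Compound 3 `CS/C(=N\C(=O)c1cccs1)NC(=O)c1cccs1` gives > 100000 nM, also a limit of the assay.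

All three values share one feature: the limit of > 100000 nM in this assay, at which 3 of the 3 values shown sit. Compound 2 arises from compound 3 by a group of 8 heavy atoms (7 carbon, 1 selenium; one six-membered aromatic ring of carbon only) in place of a group of 2 heavy atoms (1 carbon, 1 sulfur; no ring), on a carbon with a double bond to nitrogen. Because both values are limits, the step that the two limits leave unreadable from compound 3 to compound 2 cannot be read as a number. The difference between the core of compound 1 and the core of compound 3 is not broken down here.

Compound 4 `O=C(/N=C(/NC(=O)c1csc([N+](=O)[O-])c1)[Se]Cc1ccccc1)c1csc([N+](=O)[O-])c1` has not yet been measured in this assay. Within the data shown here, it arises from compound 1 by a group of 8 heavy atoms (7 carbon, 1 selenium; one six-membered aromatic ring of carbon only) in place of a group of 2 heavy atoms (1 carbon, 1 sulfur; no ring), on a carbon with a double bond to nitrogen, the same change as the one from compound 3 to compound 2, made at a place described in the same words.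

The expected step is a step that the limit leaves unreadable from compound 1 to compound 4, an estimate that rests on the unreadable step that the two limits leave unreadable from compound 3 to compound 2 and on (the limit of > 100000 nM in this assay, at which 3 of the 3 values shown sit). Compound 4 is therefore expected at 200000 nM, estimated to lie between 50000 nM and 1000000 nM, most likely reported only as a limit once more.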

Compound 4, concentration lethal to 50% of the cells: > 100000 nM
Compound 4 gave a limit, no number (the forecaster's own chance of this, stated with the estimate: 85%); the middle value is on the limit's open side.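

In this assay compound 4 gives > 100000 nM, which is a limit of the assay and not a number. Among these compounds, no step from compound 1 to compound 4 can be read from it. The compounds shown leave open whether replacing methylsulfanyl changes toxicity in this test at all, because every value stands at the same limit: the limit of > 100000 nM in this assay, at which 4 of the 4 values shown sit.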